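The compounds below may be only part of what the source reports. "The series", "measured", "known", "first", "only" and "open" are said of these compounds alone.

In an ADME assay on HEK293 cells (Homo sapiens) for antiproliferative activity, read by MTT assay, with a stated time of 72 h (a lower number here means a stronger inhibitor, a higher number a weaker inhibitor), three compounds built on a shared core have been measured so far. Compound 1 `CC(=O)/C=C/c1cnc(C)c2c1COC(C)(C)O2` gives 17000 nM, compound 2 `CCC1OCc2c(/C=C/C(C)=O)cnc(C)c2O1` gives 36000 nM, and compound 3 `CCCC1OCc2c(/C=C/C(C)=O)cnc(C)c2O1` gives 2900 nM. Compound 3 thus holds the lowest number of the three, and its gaps to the other two lie beyond the scatter.

The next compound is compound 4 `CCCCC1OCc2c(/C=C/C(C)=O)cnc(C)c2O1`, and its difference from compound 3 is methyl in place of hydrogen on a saturated chain carbon, three bonds along the chain from a saturated ring carbon. This is methyl in place of hydrogen on a saturated chain carbon, three bonds along the chain from a saturated ring carbon, which turns propyl to butyl.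

Among the compounds with values here, only one measured step bears on this change: a 12-fold lower number from compound 2 to compound 3 (1.09 log units; beyond the scatter). That large step came from methyl in place of hydrogen on a saturated chain carbon, two bonds along the chain from a saturated ring carbon. Within the data shown here, a single step sets no trend, and no measured compound carries the chain further, so a repeat of its full size is not assumed. A smaller step in the same direction is expected in this assay, though one within the scatter would be no surprise. The estimated change is a 1.9-fold lower number from compound 3 to compound 4 (0.29 log units; within the scatter). Compound 4 is expected at 1500 nM, with an estimated range from 450 nM to 5000 nM.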

Compound 4, half-maximal inhibitory concentration: 13000 nM
Compound 4: middle estimate off by 8.7-fold (0.94 log units), on the low side; the whole stated range lies below it.
By their numbers in this assay, from the lowest: compound 3; then compounds 4 and 1 (each within the scatter of the next); then compound 2.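

In this assay, extending the chain at this position does not keep paying: propyl to butyl reverses the direction of the earlier change, giving (a 4.5-fold higher number from compound 3 to compound 4 (0.65 log units; beyond the scatter)) where ethyl to propyl had given (a 12-fold lower number from compound 2 to compound 3 (1.09 log units; beyond the scatter)). The added methyl thus acts differently three bonds along the chain from the saturated ring carbon than it does two bonds along, and the single earlier step could not have shown this. The butyl chain does not return all the way to the ethyl level, since the comparison between those two reads (a 2.8-fold lower number from compound 2 to compound 4 (0.44 log units; beyond the scatter)), so among these three chains the number falls and then rises, with propyl in compound 3 at the lowest point, and no information at hand accounts for that turn.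

The compounds shown leave open whether a pentyl or longer chain would carry the number further up or level off. They also leave open whether the low number of compound 3 depends on chain length alone, a question that a branched isobutyl group, a cyclopropyl group or a propyl chain ending in an amine could address.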